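Removing an aryl amidoxime arm: cytotoxicity expected to shift

The compounds below may be only part of what the source reports. "The series", "measured", "known", "first", "only" and "open" are said of these compounds alone.

This account follows one change on a shared core, read in an ADME assay on J774.A1 cells (Mus musculus) for cytotoxicity, read by MTT assay, with a stated time of 72 h; on this read-out lower numbers stand for higher toxicity in this test and higher numbers for lower toxicity in this test. Three compounds have numbers. Compound 1 `CC1(c2ccc(-c3ccco3)cc2)CC(S(=O)(=O)c2ccc(F)cc2)=C(c2ccc(/C(N)=N\O)cc2)O1` gives 4560 nM. Compound 2 `CC1(c2ccc(-c3cccc(/C(N)=N\O)c3)cc2)CC(S(=O)(=O)c2ccc(F)cc2)=C(c2ccc(/C(N)=N\O)cc2)O1` gives 11000 nM. Compound 3 `CC1(Cc2ccccc2)CC(S(=O)(=O)c2cccc(C(F)(F)F)c2)=C(c2ccc(/C(N)=N\O)cc2)O1` gives 14500 nM. Compound 2 holds the second highest of the three numbers: compound 3 sits within the scatter of it, while compound 1 is separated by a step beyond the scatter, namely a 2.4-fold higher number from compound 1 to compound 2 (0.38 log units; beyond the scatter).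

Compound 4 `CC1(c2ccccc2)CC(S(=O)(=O)c2ccc(F)cc2)=C(c2ccc(/C(N)=N\O)cc2)O1` is not yet measured. It differs from compound 2 by a hydrogen atom in place of a group of 10 heavy atoms (7 carbon, 2 nitrogen, 1 oxygen; one six-membered aromatic ring of carbon only), on an aromatic carbon, the group leaving from a place para to a large group. Among the measured compounds shown here, the only step that bears on this position is the one from compound 1 to compound 2, where the larger group entering in place of the five-membered ring raised the number modestly. Taking that group away entirely is expected to move the number back down, probably by a modest step, though hydrogen is a smaller substituent than either ring seen so far, so the size is uncertain. Compound 4 is therefore expected to give about 5500 nM (range 2500 nM to 12000 nM), a step of a 2.0-fold lower number from compound 2 to compound 4 (0.30 log units; within the scatter), which is expected.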

Compound 4, half-maximal cytotoxic concentration: 29700 nM
The estimate for compound 4 lay 5.4-fold (0.73 log units) below the measured number, and the stated range ends below it.
By their numbers in this assay, from the lowest: compound 1; then compounds 2 and 3 (each within the scatter of the next); then compound 4.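

Taking the whole group away gave the highest number of the series in this assay, with a 2.7-fold higher number from compound 2 to compound 4 (0.43 log units; beyond the scatter), and replacing furan-2-yl with hydrogen gave a 6.5-fold higher number from compound 1 to compound 4 (0.81 log units; beyond the scatter). The earlier step alone had shown only that the larger group gave a higher number than furan-2-yl; now both ring-bearing compounds stand below the hydrogen compound, so the number at this aromatic carbon does not simply rise with the size of the group. Nothing shown here explains this order. On these data alone, it remains open whether the lower numbers of compound 1 and compound 2 come from any ring at this carbon, since a plain phenyl group does not appear among them. Equally open, as far as these compounds go, is how a single small group there, such as fluorine or an amine, would compare with hydrogen.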